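Compound 3: a new group on the carbonyl carbon

This account rests on a few compounds, and the source may have more. Where it says the series, first, only, none or still open, it means among the compounds named here.

In a functional assay on PC-3 cells (Homo sapiens) for inhibition, read by sulforhodamine B assay, with a stated time of 48 h (a higher number here means that more compound is tolerated, a lower number that less compound is tolerated), compound 1 (`O=C(Nc1cccc(-n2cc(-c3ccncc3)c(-c3ccc(Cl)c(O)c3)n2)c1)Nc1cccc(C(F)(F)F)c1`) gives > 32500 nM, which is a limit and not a number. Compound 2 (`COc1cc(-c2nn(-c3cccc(NC(=O)c4cccc(C(F)(F)F)c4)c3)cc2-c2ccncc2)ccc1Cl`) gives > 50000 nM, which is also a limit. Among the measured compounds shown here, compound 2 therefore has no exact position, and no measured step is available to calibrate a change. Compound 3 (`COc1cc(-c2nn(-c3cccc(NC(=O)Nc4ccc(Cl)c(C(F)(F)F)c4)c3)cc2-c2ccncc2)ccc1Cl`) carries (4-chloro-3-(trifluoromethyl)phenyl)amino in place of 3-(trifluoromethyl)phenyl on a carbonyl carbon. In this assay, a modest shift toward less compound being tolerated is expected, although a result that is again only a limit remains quite possible. The expected at least 1.6-fold lower number from compound 2 to compound 3 (0.22 log units; that floor lies within the scatter) is uncertain in size. For compound 3 the estimated value is 30000 nM, with an expected range from 8000 nM to 60000 nM.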

Compound 3, concentration lethal to 50% of the cells: > 32500 nM
Compound 3: only a limit was reported (the forecaster's own chance of this, stated with the estimate: 55%); at least 1.0-fold (0.03 log units) between middle value and limit.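

In this assay compound 3 gives > 32500 nM, a limit and not a number. Compound 2 is also reported only as a limit, and the step between compound 2 and compound 3 cannot be read. Exact values for compounds 1, 2 and 3 remain open, as does any effect of the exchanged group.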